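A few compounds are considered here, and "the series" means these few. Any claim that something is new, unique, unknown or untested is made for them only; others in the source may bear on it.

Two compounds of the series carry numbers in a functional assay on MCF7 cells (Homo sapiens) for antiproliferative activity, read by MTT assay, with a stated time of 48 h, tested at 12.5 uM; on this read-out lower numbers stand for a stronger effect and higher numbers for a weaker effect at the one concentration tested. Compound 1 `C[C@@H](O)CCn1nc2c(Br)c(Br)c(Br)c(Br)c2n1` gives 86% and stands lowest of the two; compound 2 `OC(CCn1nc2c(Br)c(Br)c(Br)c(Br)c2n1)c1ccccc1` gives 113%, higher by a margin beyond the scatter. Compound 3 `C[C@H](O)CCn1nc2c(Br)c(Br)c(Br)c(Br)c2n1` is not yet measured. It differs from compound 1 as follows: the two compounds have the same atoms and bonds and differ only in configuration as drawn: 1 of 1 stereo elements differ; a stereocentre at a saturated chain carbon is drawn R in compound 1 and S in compound 3. Going by the values given here, no step between measured compounds is known, so nothing itself sizes this change; for a difference in configuration alone, no step beyond the scatter is expected in this assay in either direction. Compound 3 is expected to give 88%, within 70% to 106%. The expected step is a number 2 percentage points higher from compound 1 to compound 3 (within the scatter).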

Compound 3, a percentage reported as activity, at one concentration (the size of the read-out at that concentration, not a potency): 100%
Compound 3: the middle estimate sits 12 percentage points below what was measured, and the stated range covers the measured number.
By their numbers in this assay, from the lowest: compound 1; then compound 3; then compound 2.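

In this assay the configuration at the saturated chain carbon is not neutral: going from R to S gives a number 14 percentage points higher from compound 1 to compound 3 (beyond the scatter). Going by these compounds alone, this modest step is the first that can be sized, and it gives a scale for a change of configuration at this position. It belongs to the stereocentre alone because no other part of the structure changes: the fact that compounds 1 and 3 differ only in the configuration as drawn.

As far as these compounds go, whether a step of similar size appears with an amine in place of the hydroxyl group, or with a longer chain, remains open. From the compounds shown here alone, the way in which configuration acts on the read-out also remains open.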